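The compounds below may be only part of what the source reports. "The series", "measured", "known", "first", "only" and "open" are said of these compounds alone.

Measured compounds:
compound 1 `Cc1cc(=O)n(-c2ccccc2OC(F)(F)F)nc1C(=O)Nc1ccc(Oc2ncnc3ccsc23)c(F)c1` — 5720 nM
compound 2 `Cc1cc(=O)n(-c2ccc(F)cc2)nc1C(=O)Nc1ccc(Oc2ncnc3ccsc23)c(F)c1` — 580 nM
compound 3 `Cc1cc(=O)n(-c2ccc(F)c(F)c2)nc1C(=O)Nc1ccc(Oc2ncnc3ccsc23)c(F)c1` — 4590 nM

All three values come from a functional assay on A549 cells (Homo sapiens) for cytotoxicity, read by MTT assay, with a stated time of 72 h; a lower number here means a stronger inhibitor, a higher number a weaker inhibitor. Compound 1 gives the highest number of the three in this assay; compound 3 sits nearest to it, and compound 2 furthest. The two steps that reach beyond the scatter both turn on the aryl group on the aromatic nitrogen: a 9.9-fold lower number from compound 1 to compound 2 (0.99 log units; beyond the scatter) and a 7.9-fold higher number from compound 2 to compound 3 (0.90 log units; beyond the scatter), whereas a 1.2-fold lower number from compound 1 to compound 3 (0.10 log units; within the scatter) stays within the scatter.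

Compound 4 `Cc1cc(=O)n(-c2ccccc2OC(F)(F)F)nc1C(=O)Nc1ccc(Oc2ncnc3sccc23)c(F)c1` is not yet measured. It keeps every atom of compound 1 and differs only in how the bicyclic group on the ether oxygen is joined: a group of 9 heavy atoms (6 carbon, 2 nitrogen, 1 sulfur; one five-membered aromatic ring with 1 hetero atom, one six-membered aromatic ring with 2 hetero atoms) in place of a group of 9 heavy atoms (6 carbon, 2 nitrogen, 1 sulfur; one five-membered aromatic ring with 1 hetero atom, one six-membered aromatic ring with 2 hetero atoms), on an oxygen on an aromatic ring. Within the data shown here, none of the measured steps touches this part of the molecule; all of them vary the aryl group on the aromatic nitrogen, so no step bears directly on the change to compound 4. With nothing to point in either direction, the expectation is a step of no clear size beyond the scatter, and the estimate for compound 4 in this assay is therefore anchored on compound 1, with a wide range to reflect the lack of any comparable step: a 1.0-fold lower number from compound 1 to compound 4 (0.02 log units; within the scatter). On that basis compound 4 is estimated at 5500 nM, with a range from 1500 nM to 20000 nM.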

Compound 4, half-maximal inhibitory concentration: > 40000 nM
Compound 4 gave a limit, no number (the forecaster's own chance of this, stated with the estimate: 10%); at least 7.2-fold (0.86 log units) between middle value and limit.
By their numbers in this assay, from the lowest: compound 2; then compounds 3 and 1 (each within the scatter of the next). At a limit, above all of these: compound 4.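

In this assay compound 4 gives > 40000 nM, which is a limit of the assay and not a number. Joining the bicyclic group to the ether oxygen differently gives an at least 6.9-fold higher number from compound 1 to compound 4 (0.84 log units; beyond the scatter), although the group that leaves and the group that enters have the same atoms, the same ring types, the same counts of hydrogen-bond donors and acceptors, and no net charge. The earlier compounds varied only the aryl group on the aromatic nitrogen, so this is the only evidence shown that the group on an oxygen on an aromatic ring also matters in this assay, and here a rearrangement within that group alone is enough to produce a step beyond the scatter.

On these data alone, the true size of the step stays unknown at a limit, and it remains open whether the same change would act in the same way with the 4-fluorophenyl group of compound 2 or the 3,4-difluorophenyl group of compound 3 in place of the 2-(trifluoromethoxy)phenyl group. Also open, as far as these compounds go, is how the series would respond to an amine or a carboxylic acid on the bicyclic group.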